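The source may report more compounds than this note shows. Statements on the series, on what has been measured and on what is new or still open speak of the compounds shown alone.

Of the compounds shown here, two of one series have so far been tested for inhibition of the flavin-containing amine oxidase. Compound 1 `Cc1ccc2oc(-c3cccc(Br)c3)cc2c1` carries a methyl on its fused core together with a bromophenyl group. In an assay on cells for inhibition of Amine oxidase [flavin-containing] A (Homo sapiens), read by fluorescence and Amplex Red, with a stated time of 15 min (on this read-out lower numbers stand for stronger inhibition and higher numbers for weaker inhibition), compound 1 gives > 100000 nM, which is a limit of the assay and not a number. Compound 2 `Cc1cccc2cc(-c3cccc(Br)c3)oc12` carries the same methyl on a different aromatic carbon of the fused core. In this assay compound 2 gives > 100000 nM, again a limit rather than a measured number. For the measured compounds named here, compound 2 thus stands at the limit of > 100000 nM in this assay, at which 2 of the 2 values shown sit, as does the only other value shown, and the numbers do not separate the two. The unmeasured compound 3 `Brc1cccc(-c2cc3ccccc3o2)c1` differs from compound 2 in one place: hydrogen in place of methyl on an aromatic carbon. Going by the values given here, no step between measured compounds exists to guide the size of this change. Both values shown are limits. The removal of the methyl is expected to give no step beyond the scatter in this assay, and a further limit is the most likely outcome. Compound 3 is therefore estimated at 150000 nM, within 30000 nM to 600000 nM, the expected step being a step that the limit leaves unreadable from compound 2 to compound 3.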

Compound 3, half-maximal inhibitory concentration: 100000 nM
Compound 3: the middle estimate sits 1.5-fold (0.18 log units) above what was measured; measured number inside the range.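

In this assay compound 3, with hydrogen in place of the methyl, gives 100000 nM. The two methyl compounds gave only limits of the assay. The change to hydrogen gives a number no higher from compound 2 to compound 3 (the limit leaves the size open), and it likewise gives a number no higher from compound 1 to compound 3 (the limit leaves the size open). The sizes of these steps cannot be read, because their values mark the end of the assay's range and not a size: the limit of > 100000 nM in this assay, at which 2 of the 3 values shown sit. What the result adds is that the core without any methyl, with hydrogen on both aromatic carbons that carry a methyl in the other two compounds, also stays at the weak end of this read-out, so neither methyl placement nor its removal shows any readable gain or loss in inhibition.

The compounds shown therefore leave open whether any change on this core can move inhibition at all, since all three sit at the same weak end and give no step of readable size. Going by these compounds, it remains open whether an amine or a carboxylic acid on the core, a longer chain in place of the methyl, or a group other than bromine on the phenyl ring would give a value clearly stronger than that of compound 3 .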